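Swapping Nitro for Chloro on a Trimethoxyphenyl Amide

The source may report more compounds than this note shows. Statements on the series, on what has been measured and on what is new or still open speak of the compounds shown alone.

Compound 1 `C/C=C/C(=O)N(Cc1ccc(OC)c([N+](=O)[O-])c1)c1cc(OC)c(OC)c(OC)c1` is the stronger of the two measured compounds: in a functional assay on MGC-803 cells (Homo sapiens) for inhibition, read by MTT assay, with a stated time of 48 h (on this read-out lower numbers stand for stronger inhibition and higher numbers for weaker inhibition), compound 1 gives 590 nM, whereas compound 2 `COc1cc(NCc2cccc(O)c2)cc(OC)c1OC` gives 57600 nM, a gap well beyond the usual scatter. Compound 3 `C/C=C/C(=O)N(Cc1ccc(OC)c(Cl)c1)c1cc(OC)c(OC)c(OC)c1` differs from compound 1 only by chloro in place of nitro on an aromatic carbon. Among the measured compounds shown here, no measured pair shows this exchange, so there is no direct precedent to lean on. The step is therefore expected to be small and uncertain in direction, with a slight lean toward weaker inhibition, as a 1.5-fold higher number from compound 1 to compound 3 (0.18 log units; within the scatter). Compound 3 is estimated at 900 nM, with a likely range from 250 nM to 3500 nM.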

Compound 3, half-maximal inhibitory concentration: 7100 nM
Beside the measured number, compound 3's estimate is 7.9-fold (0.90 log units) below it; the measured number lies above the stated range.
By their numbers in this assay, from the lowest: compound 1; then compound 3; then compound 2.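

This aromatic carbon, ortho to a methoxy group, proves sensitive: in this assay, chloro in place of nitro gives a 12-fold higher number from compound 1 to compound 3 (1.08 log units; beyond the scatter) and so a clear loss of inhibition from one local change. Compound 1 and compound 2 differ in more than one place, so they could not isolate this position. Nothing measured here explains the size of this step.

Going by these compounds, whether the nitro group is uniquely favourable at this carbon remains open. A nitrile or a trifluoromethyl group there could land near compound 1, near compound 3, or elsewhere.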